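The source may report more compounds than this note shows. Statements on the series, on what has been measured and on what is new or still open speak of the compounds shown alone.

The study is followed in a functional assay on DLD-1 cells (Homo sapiens) for antiproliferative activity, read by CellTiter-Glo, with a stated time of 72 h; a lower number here means a stronger inhibitor, a higher number a weaker inhibitor. For the measured compounds named here, compound 1 `CC1CCN(C2CCN(S(=O)(=O)c3cccc(-c4ccccc4C(F)(F)F)c3)CC2)CC1` gives 10 nM in this assay, the lowest of the two numbers known so far, and its gap to the nearest neighbour lies beyond the usual scatter of repeated measurements. That neighbour, compound 2 `COc1ccc(S(=O)(=O)N2CCC(N3CCC(C)CC3)CC2)cc1OC`, gives 138 nM in this assay. For compound 3 `Cc1cc(C)c(S(=O)(=O)c2ccc(N3CCC(C)CC3)cc2)c(C)c1` this assay reports only a limit, > 5000 nM, and no number (the limit of > 5000 nM in this assay, at which 1 of the 3 values shown sits).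

Compound 4 `CC1CCN(C2CCN(S(=O)(=O)c3cccc(-c4ccc5ccccc5c4)c3)CC2)CC1` has not yet been measured. It differs from compound 1 in one place: naphthalen-2-yl in place of 2-(trifluoromethyl)phenyl on an aromatic carbon. Going by the values given here, no step between two measured compounds in this assay parallels this change, so the expectation rests on compound 1 alone. The rest of compound 1 is kept unchanged, and the step is expected to be small, possibly in either direction and not far beyond the scatter. The expected step is a 2.0-fold higher number from compound 1 to compound 4 (0.30 log units; within the scatter). Compound 4 is therefore estimated at 20 nM in this assay, with a likely range from 5 nM to 80 nM.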

Compound 4, half-maximal inhibitory concentration: 2 nM
The estimate for compound 4 lay 10-fold (1.00 log units) above the measured number; the measured number lies below the stated range.
By their numbers in this assay, from the lowest: compound 4; then compound 1; then compound 2. At a limit, above all of these: compound 3.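

The step of a 5.0-fold lower number from compound 1 to compound 4 (0.70 log units; beyond the scatter) in this assay shows that this aromatic carbon, meta to a large group, does not need the 2-(trifluoromethyl)phenyl group for a low number. Naphthalen-2-yl has the same count of heavy atoms but only carbon, with a second six-membered aromatic ring in place of the trifluoromethyl group, and the number still falls modestly, beyond the scatter. The data shown give no cause for this step.

What remains open is how much of the step belongs to the second ring and how much to the loss of the trifluoromethyl group, since plain phenyl is not among the compounds shown. Also open, on these data alone, is how this position would respond to naphthalen-1-yl, or to an aromatic ring carrying an amine or a carboxylic acid.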